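Fluoro for methoxy on a second dienone core

A few compounds are considered here, and "the series" means these few. Any claim that something is new, unique, unknown or untested is made for them only; others in the source may bear on it.

Measured compounds:
compound 1 `COc1cc(C=C(C(=O)/C=C/c2cccc(OC)c2OC)C(=O)/C=C/c2cccc(OC)c2OC)ccc1O`: 280 nM
compound 2 `COc1cccc(/C=C/C(=O)C(=Cc2ccc(O)c(F)c2)C(=O)/C=C/c2cccc(OC)c2OC)c1OC`: 260 nM
compound 3 `COc1ccc(/C=C/C(=O)C(=Cc2ccc(O)c(OC)c2)C(=O)/C=C/c2ccc(OC)cc2OC)c(OC)c1`: 970 nM

In a functional assay on CNE-2 cells (Homo sapiens) for antiproliferative activity, read by sulforhodamine B assay, with a stated time of 48 h (a higher number here means a weaker inhibitor, a lower number a stronger inhibitor), compound 1 gives 280 nM and compound 2 gives 260 nM. The two differ by one change, (fluoro in place of methoxy on an aromatic carbon), and the step of a 1.1-fold lower number from compound 1 to compound 2 (0.03 log units; within the scatter) is within the scatter, so the two values cannot be told apart. Compound 3, with a different core, gives the highest number of the three in this assay; the difference between the two cores of compound 3 and compound 1 is not broken down here, and its gap to each of compound 1 and compound 2 lies beyond the scatter.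

Compound 4 `COc1ccc(/C=C/C(=O)C(=Cc2ccc(O)c(F)c2)C(=O)/C=C/c2ccc(OC)cc2OC)c(OC)c1` is not yet measured. Among the compounds with values here, it differs from compound 3 by fluoro in place of methoxy on an aromatic carbon, which is the same change as the one from compound 1 to compound 2, set on the same kind of place. Since that change left the number unchanged within the scatter, as the step of a 1.1-fold lower number from compound 1 to compound 2 (0.03 log units; within the scatter) shows, compound 4 is expected to sit close to compound 3, with an estimated step of a 1.1-fold lower number from compound 3 to compound 4 (0.03 log units; within the scatter). For compound 4 the expected value in this assay is 900 nM, estimated to lie between 450 nM and 1800 nM.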

Compound 4, half-maximal inhibitory concentration: 2830 nM
Beside the measured number, compound 4's estimate is 3.1-fold (0.50 log units) below it, outside the stated range (above it).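

In this assay, fluoro in place of methoxy, which turns the 4-hydroxy-3-methoxyphenyl group into 3-fluoro-4-hydroxyphenyl, gives a 2.9-fold higher number from compound 3 to compound 4 (0.47 log units; beyond the scatter), so the change does not carry over as a constant step between these two cores: the same change on two cores in this assay, a 1.1-fold lower number (0.03 log units; within the scatter) from compound 1 to compound 2 and a 2.9-fold higher number (0.47 log units; beyond the scatter) from compound 3 to compound 4, 3.1-fold (0.50 log units) apart, beyond the scatter of two such steps The outcome of the change on the core of compound 1 was therefore no reliable guide to its outcome on the core of compound 3. Within the data shown here, these results do not show which feature of the two cores accounts for the difference, and with only one pair on each core they give no general rule for this series.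

The compounds shown leave open how the same change would behave on further cores. They also leave open whether a different group in the same place, such as chloro, an amine or a longer alkoxy chain like ethoxy, would follow the methoxy or the fluoro compounds on each core.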